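Amine arm exchange on the shared core: compound 4

A few compounds are considered here, and "the series" means these few. Any claim that something is new, unique, unknown or untested is made for them only; others in the source may bear on it.

Measured so far:
compound 1 `FC(F)(F)c1ccc(Nc2nc(N3CCN(C4CCC4)CC3)nc3c2CCN(c2ncccc2C(F)(F)F)CC3)cc1`, 161 nM
compound 2 `CCC(CC)N1CCN(c2nc3c(c(Nc4ccc(C(F)(F)F)cc4)n2)CCN(c2ncccc2C(F)(F)F)CC3)CC1`, 185 nM
compound 3 `CN1CCCCC1CNc1nc2c(c(Nc3ccc(C(F)(F)F)cc3)n1)CCN(c1ncccc1C(F)(F)F)CC2`, 2280 nM

In a functional assay on HEK293 cells for antagonist activity at transient receptor potential cation channel subfamily V member 1 (Rattus norvegicus), read by FLIPR and calcium flux (a higher number here means a weaker inhibitor, a lower number a stronger inhibitor), compound 2 stands second highest of the three numbers, within the scatter of compound 1 and far from compound 3. Compound 4 `FC(F)(F)c1ccc(Nc2nc(NC3CCCNC3)nc3c2CCN(c2ncccc2C(F)(F)F)CC3)cc1` differs from compound 2 by (piperidin-3-yl)amino in place of 4-(pentan-3-yl)piperazin-1-yl on an aromatic carbon. Among the measured compounds shown here, the steps that bear on this are those to compound 3, where an amino-linked ring amine also replaced the piperazine arm: a 12-fold higher number from compound 2 to compound 3 (1.09 log units; beyond the scatter) and a 14-fold higher number from compound 1 to compound 3 (1.15 log units; beyond the scatter). A weakening of similar size is therefore expected in this assay, with an 8.1-fold higher number from compound 2 to compound 4 (0.91 log units; beyond the scatter). Compound 4 is estimated at 1500 nM, range 500 nM to 5000 nM.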

Compound 4, half-maximal inhibitory concentration: > 5000 nM
Compound 4 gave a limit, no number; the forecaster's own chance of this, stated with the estimate: 5%; at least 3.3-fold (0.52 log units) between middle value and limit.
By their numbers in this assay, from the lowest: compounds 1 and 2 (each within the scatter of the next); then compound 3. At a limit, above all of these: compound 4.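

In this assay compound 4 gives only a limit, not a number: the limit of > 5000 nM in this assay, at which 1 of the 4 values shown sits. The (piperidin-3-yl)amino arm falls well behind both piperazine arms on this aromatic carbon between two ring nitrogen atoms, with an at least 27-fold higher number from compound 2 to compound 4 (1.43 log units; beyond the scatter) and an at least 31-fold higher number from compound 1 to compound 4 (1.49 log units; beyond the scatter). It also trails the other amino-linked ring amine, with an at least 2.1-fold higher number from compound 3 to compound 4 (0.34 log units; beyond the scatter), so both amino-linked arms sit clearly behind both piperazine arms.

From the compounds shown here alone, the true size of these steps remains open beyond the limit. Also open, going by these compounds, is whether the loss follows the amino link or the free ring amine, a question that (1-methylpiperidin-3-yl)amino or unsubstituted piperazin-1-yl would bear on.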